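Replacing trifluoromethoxy with dimethylamino in compound 3

The compounds below may be only part of what the source reports. "The series", "measured", "known", "first", "only" and "open" are said of these compounds alone.

In a functional assay on SiHa cells (Homo sapiens) for inhibition, read by sulforhodamine B assay (a higher number here means a weaker inhibitor of growth, a lower number a stronger inhibitor of growth), compound 1 `Cc1ccc2[nH]c(-c3ccc(-c4ccc(-c5ccc(N(C)C)cc5)cc4)cc3)nc2c1` gives 7110 nM, compound 2 `Oc1cccc2[nH]c(-c3ccc(-c4ccc(-c5ccc(C(F)(F)F)cc5)cc4)cc3)nc12` gives 3720 nM and compound 3 `Oc1cccc2[nH]c(-c3ccc(-c4ccc(-c5ccc(OC(F)(F)F)cc5)cc4)cc3)nc12` gives 8410 nM. Compound 3 lies within the scatter of compound 1 and beyond it from compound 2. Compound 4 `CN(C)c1ccc(-c2ccc(-c3ccc(-c4nc5c(O)cccc5[nH]4)cc3)cc2)cc1` puts dimethylamino in place of trifluoromethoxy on an aromatic carbon. Within the data shown here, the only measured step on this position is modest, a 2.3-fold higher number from compound 2 to compound 3 (0.35 log units; beyond the scatter), and it involves a different exchange. Compound 1 carries the same dimethylamino group on a different core and gives 7110 nM, so no large shift is expected in this assay. The expected step, a 1.3-fold lower number from compound 3 to compound 4 (0.11 log units; within the scatter), stays within the scatter. Compound 4 is estimated at 6500 nM, with a range of 2800 nM to 15000 nM.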

Compound 4, concentration for 50% growth inhibition: 6240 nM
Compound 4: middle estimate off by 1.0-fold (0.02 log units), on the high side; the range from low to high includes it.
By their numbers in this assay, from the lowest: compounds 2, 4, 1 and 3 (each within the scatter of the next, the first and the last beyond it).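

In this assay, dimethylamino on this aromatic carbon sits within the scatter of both fluorinated groups (a 1.3-fold lower number from compound 3 to compound 4 (0.13 log units; within the scatter)) and (a 1.7-fold higher number from compound 2 to compound 4 (0.22 log units; within the scatter)), although those two groups stand apart (a 2.3-fold higher number from compound 2 to compound 3 (0.35 log units; beyond the scatter)). With dimethylamino held fixed, 4-hydroxy-1H-benzimidazol-2-yl in place of 5-methyl-1H-benzimidazol-2-yl also stays within the scatter (a 1.1-fold lower number from compound 1 to compound 4 (0.06 log units; within the scatter)). Nothing available explains these small differences.

Still open, going by these compounds, is whether a carboxylic acid, a primary amine or a longer alkyl chain at this position would move the number beyond the scatter. Also open, on these data alone, is whether any such group would reach a number clearly lower than that of compound 2 (3720 nM).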